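Thiophen-2-yl for Phenyl on the Shared Core

The source may hold more compounds than are shown below. What is called first, only, known or untested is meant among the compounds shown, and "the series" means these compounds.

Compound 1, `O=C(Nc1ccccc1)O/N=C1\N[C@H](CO)[C@@H](O)[C@H](O)[C@H]1O`: > 100000 nM
Compound 2, `O=C(Nc1ccc(Oc2ccccc2)cc1)O/N=C1\N[C@H](CO)[C@@H](O)[C@H](O)[C@H]1O`: > 100000 nM
Compound 3, `O=C(Nc1c(Cl)cccc1C(F)(F)F)O/N=C1\N[C@H](CO)[C@@H](O)[C@H](O)[C@H]1O`: > 100000 nM

Of the compounds shown here, three built on the core of compound 1 have been tested in an assay on isolated protein for inhibition of alpha-galactosidase (Coffea arabica) (a higher number here means a weaker inhibitor, a lower number a stronger inhibitor), and none gave a number. Compound 1 reaches only a limit of the assay in this assay. Compound 2 likewise stops at a limit. Compound 3 also stops at a limit. All three sit at the same boundary, (the limit of > 100000 nM in this assay, at which 3 of the 3 values shown sit), so compound 1 stands where every measured compound stands, with no number to rank it. Among the measured compounds shown here, the one single-point change between measured compounds, a step that the two limits leave unreadable from compound 1 to compound 2, cannot be read because both of its values are limits.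

Compound 4, `O=C(Nc1cccs1)O/N=C1\N[C@H](CO)[C@@H](O)[C@H](O)[C@H]1O`, differs from compound 1 by thiophen-2-yl in place of phenyl on an amide-type nitrogen. For the measured compounds named here, no measured step bears on this change, and the only measured step, from compound 1 to compound 2, is unreadable. Compound 4 is therefore expected to remain at the limit in this assay, with an estimated 150000 nM and a range of 50000 nM to 1000000 nM. The expected step that the limit leaves unreadable from compound 1 to compound 4 is thus estimated as none beyond the scatter.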

Compound 4, half-maximal inhibitory concentration: > 100000 nM
Compound 4 gave a limit, no number; the forecaster's own chance of this, stated with the estimate: 85%; the middle value does not contradict the limit.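

Compound 4 stops at a limit, as compound 1 does, so no step can be read between compound 1 and compound 4: the limit of > 100000 nM in this assay, at which 4 of the 4 values shown sit.

The compounds shown leave open whether any group on the amide-type nitrogen of the shared core can give a number in this assay.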